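Lengthening the Piperazine Linker by One Carbon

A few compounds are considered here, and "the series" means these few. Any claim that something is new, unique, unknown or untested is made for them only; others in the source may bear on it.

Compound 1 `COc1c(OCCCN2CCNCC2)cc(O)c2c(=O)cc(-c3ccccc3)oc12` carries a piperazine ring tethered through a three-carbon chain to an oxygen on the shared core. Within the data shown here, in a functional assay on A549 cells (Homo sapiens) for cytotoxicity, read by MTT assay, with a stated time of 48 h (a lower number here means a stronger inhibitor, a higher number a weaker inhibitor), compound 1 gives 10100 nM; this is the only single number among the three results, so compound 1 stands as the one firm point of reference. Compound 2 `COc1c(O)cc(O)c2c(=O)cc(-c3ccc(Cl)cc3)oc12`, which bears a chlorine on its pendant phenyl ring and lacks the chain, has no result in this assay: "not determined" (no result reported). Compound 3 `CN1CCN(CCCCOc2c(O)cc(O)c3c(=O)cc(-c4ccccc4)oc23)CC1`, with a four-carbon chain to a methylated piperazine and a hydroxy in place of the methoxy, reaches only a limit of this assay, > 100000 nM, so no number exists for it. Compound 3 differs from compound 1 in more than one place, and its result shows only that a much weaker outcome occurs in this series.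

Compound 4 `COc1c(OCCCCN2CCNCC2)cc(O)c2c(=O)cc(-c3ccccc3)oc12` has not yet been measured. It differs from compound 1 by (piperazin-1-yl)methyl in place of piperazin-1-yl on a saturated chain carbon, three bonds along the chain from an oxygen on an aromatic ring. Among the measured compounds shown here, no measured pair shows this single change, so the size of the step rests on expectation alone. The step of a 1.5-fold higher number from compound 1 to compound 4 (0.17 log units; within the scatter) is expected to be small, in the weakening direction, and to sit near the edge of the usual scatter. Compound 4 is therefore estimated at 15000 nM, with a range from 5000 nM to 60000 nM.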

Compound 4, half-maximal inhibitory concentration: 1740 nM
Estimate against measurement, compound 4: 8.6-fold (0.94 log units) above, outside the stated range (below it).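

Adding one carbon to the chain, so that 3-(piperazin-1-yl)propyl becomes 4-(piperazin-1-yl)butyl, gives a 5.8-fold lower number from compound 1 to compound 4 (0.76 log units; beyond the scatter) in this assay, which shows that the chain length at this position can change the result beyond the usual scatter, and that here the longer chain goes with the stronger result. Differing from compound 1 in more than one place, compound 3 also has a longer chain, but it gives > 100000 nM, which is a limit of the assay and not a number, so it can neither support nor contradict this single step. The compounds shown offer no explanation for why the added carbon has this effect.

Among these compounds, two chain lengths make only one step and do not define a trend, so it remains open whether a shorter 2-(piperazin-1-yl)ethyl chain or a longer 5-(piperazin-1-yl)pentyl chain would continue this direction or reverse it. From the compounds shown here alone, it is also open whether the same added carbon would have a similar effect with a different group at the end of the chain, such as a morpholine ring or a dimethylamine in place of the piperazine ring.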